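The source may report more compounds than this note shows. Statements on the series, on what has been measured and on what is new or still open speak of the compounds shown alone.

Measured so far:
compound 1, `COc1ccc(NC(=O)c2sc(COc3ccc(Cl)c(C)c3)nc2C)cc1`: -7.6%
compound 2, `Cc1ccc(C)c(OCc2nc(C)c(C(=O)Nc3cccc(Cl)c3)s2)c1`: 17.1%

In an assay for binding affinity to CDK8/Cyclin C (Homo sapiens), read by FRET and LanthaScreen, with stated times of 20 min and 2 h, tested at 10 uM (on this read-out higher numbers stand for more inhibition at the one concentration tested (going by the name of the read-out) and lower numbers for less inhibition), compound 1 gives -7.6%, a reading at or around no inhibition. In this assay, within the data shown here, compound 2 gives 17.1%, the higher of the two numbers; the gap down to compound 1 lies beyond the usual scatter, so compound 2 stands clearly above its only neighbour. Among the measured compounds shown here, the two compounds differ in more than one place at once, so no single step between measured compounds can be read from them.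

Compound 3, `Cc1ccc(C)c(OCc2nc(C)c(C(=O)Nc3cccc(F)c3)s2)c1`, is still to be measured. It differs from compound 2 in exactly one place: fluoro in place of chloro on an aromatic carbon. For the measured compounds named here, nothing among the measured compounds shows what this particular exchange does in this assay, so the expectation rests on the starting point alone. With only the value of compound 2 to lean on, the step of a number 7.1 percentage points lower from compound 2 to compound 3 (within the scatter) is expected to be small, likely no larger than the scatter, with a slight lean downward. Compound 3 is therefore estimated at 10%, within a range from -10% to 30%.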

Compound 3, a percentage reported as inhibition, at one concentration (the size of the read-out at that concentration, not a potency): 12.1%
Estimate against measurement, compound 3: 2.1 percentage points below; the range from low to high includes it.
By their numbers in this assay, from the lowest: compound 1; then compounds 3 and 2 (each within the scatter of the next).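

In this assay, putting fluoro in place of chloro on the aromatic carbon gives a number 5 percentage points lower from compound 2 to compound 3 (within the scatter). Among these compounds, this is the first comparison here that isolates a single place, as the earlier pair differs in more than one, and it shows that the 3-chlorophenyl and 3-fluorophenyl groups cannot be told apart in this read-out. Compound 2 at 17.1% and compound 3 at 12.1% therefore count as the same level of inhibition at the one concentration tested, so this particular exchange, on this compound, leaves the reading unresolved from repeat-to-repeat variation. Nothing shown here offers an explanation for how these two compounds read.

Still open, from the compounds shown here alone, is whether a group of a different kind on this aromatic carbon, such as an amine, a carboxylic acid or a nitrile, would move the reading by more than the scatter. A single pair also cannot tell whether fluoro in place of chloro would read the same way on another aromatic carbon or on a compound with a different substitution pattern.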